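Aryl Swap on a Triazole Nitrogen in a Spiro Series

The source may report more compounds than this note shows. Statements on the series, on what has been measured and on what is new or still open speak of the compounds shown alone.

Compound 1, `N#CC1=C(N)Oc2c(c3nc4ccccc4nc3c3ccccc23)C12C(=O)N(Cc1cnnn1-c1ccc(F)cc1)c1ccccc12`, and compound 2, `CC(=O)Nc1ccc(-n2nncc2CN2C(=O)C3(C(C#N)=C(N)Oc4c(N)cc5nc6ccccc6nc5c43)c3ccccc32)cc1`, share one core and were both tested in a functional assay on MCF7 cells (Homo sapiens) for antiproliferative activity, read by MTT assay, with a stated time of 48 h; a higher number here means a weaker inhibitor, a lower number a stronger inhibitor. In this assay compound 1 reaches no number and gives only a limit, > 50000 nM. In this assay compound 2 likewise stops at a limit, > 50000 nM, which is not a number. Where compound 2 stands is therefore fixed by the limit of > 50000 nM in this assay, at which 2 of the 2 values shown sit; no measured step separates the two compounds, and both values shown are limits.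

Compound 3, `N#CC1=C(N)Oc2c(N)cc3nc4ccccc4nc3c2C12C(=O)N(Cc1cnnn1-c1c(Cl)cc(Cl)cc1Cl)c1ccccc12`, has not yet been measured in this assay. It differs from compound 2 in one place: 2,4,6-trichlorophenyl in place of 4-acetamidophenyl on an aromatic nitrogen. The group that leaves carries a hydrogen-bond donor and an acceptor; the group that enters carries neither.

Going by the values given here, with both measured values at a limit and no measured step to lean on, the expected step is an at least 1.1-fold lower number from compound 2 to compound 3 (0.04 log units; that floor lies within the scatter), which is no change beyond the scatter. For compound 3 the estimated value in this assay is 45000 nM, with a range from 10000 nM to 100000 nM, and a further limit is the more likely outcome.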

Compound 3, half-maximal inhibitory concentration: 37800 nM
For compound 3 the middle estimate is 1.2-fold (0.08 log units) above the measured one; the range from low to high includes it.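

In this assay compound 3 gives 37800 nM, the only number among the compounds shown, so replacing 4-acetamidophenyl with 2,4,6-trichlorophenyl on the aromatic nitrogen yields a measured value rather than a limit. The change reads as an at least 1.3-fold lower number from compound 2 to compound 3 (0.12 log units; that floor lies within the scatter), which gives only a floor for the step, and how far the true step reaches cannot be read. The entering group carries no hydrogen-bond donor or acceptor, so neither is required at this position for a value to be measured, while compound 2 still anchors the comparison only through a limit: the limit of > 50000 nM in this assay, at which 2 of the 3 values shown sit.

The compounds shown leave open which part of the change matters, whether the loss of the acetamide or the arrival of the chlorines, and a plain phenyl or a phenyl carrying a single chlorine on this nitrogen would begin to separate the two. They also leave open whether a different kind of substituent on the aryl ring, such as an amine or a carboxylic acid, would give a number clearly beyond the scatter from compound 3.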